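The source may hold more compounds than are shown below. What is called first, only, known or untested is meant among the compounds shown, and "the series" means these compounds.

Measured in a functional assay on NB1 cells (Homo sapiens) for cytotoxicity, read by MTT assay, with a stated time of 3 days; a higher number here means a weaker inhibitor, a lower number a stronger inhibitor:
- Compound 1 `N#Cc1c(Nc2ccccn2)nc(SCc2nc3ccccc3[nH]2)nc1-c1ccccc1`: 3.9 nM
- Compound 2 `N#Cc1c(NC(N)=S)nc(SCc2nc3ccccc3[nH]2)nc1-c1ccccc1`: 11.9 nM
- Compound 3 `N#Cc1c(NC(N)=O)nc(SCc2nc3ccccc3[nH]2)nc1-c1ccccc1`: 7.35 nM

The three compounds share one core and differ only in the group on a nitrogen attached to the aromatic ring. Compound 3 lies within the usual scatter of both others, as a 1.9-fold higher number from compound 1 to compound 3 (0.28 log units; within the scatter) and a 1.6-fold lower number from compound 2 to compound 3 (0.21 log units; within the scatter) show. Only a 3.1-fold higher number from compound 1 to compound 2 (0.48 log units; beyond the scatter) goes beyond that scatter, and it is modest.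

Compound 4 `CN1CCN(c2nc(SCc3nc4ccccc4[nH]3)nc(-c3ccccc3)c2C#N)CC1` has not yet been measured. It carries 4-methylpiperazin-1-yl in place of ureido on an aromatic carbon. Going by the values given here, this is a larger change than any of the measured ones, since none of the measured compounds has a non-aromatic ring at this place. The measured steps therefore bear on it only indirectly. They show that swapping a ring for an open chain at this place moved the number little, as in a 1.9-fold higher number from compound 1 to compound 3 (0.28 log units; within the scatter). No step beyond the scatter is therefore expected in this assay, and the data favour no direction. The estimate is a 1.1-fold higher number from compound 3 to compound 4 (0.04 log units; within the scatter), which is an expected step only. Going by these compounds, for compound 4 the expected value is 8 nM, with an estimated range from 2.5 nM to 30 nM, kept wide because this ring is untested here.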

Compound 4, half-maximal inhibitory concentration: 2.4 nM
For compound 4 the middle estimate is 3.3-fold (0.52 log units) above the measured one; measured number below the stated range.
By their numbers in this assay, from the lowest: compounds 4, 1, 3 and 2 (each within the scatter of the next, the first and the last beyond it).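

In this assay, compound 4 shows that this aromatic carbon, ortho to a cyano group, can carry a non-aromatic ring with 0 hydrogen-bond donors without any loss, whereas every earlier compound has a hydrogen-bearing nitrogen attached there. The change to 4-methylpiperazin-1-yl gives a 3.1-fold lower number from compound 3 to compound 4 (0.49 log units; beyond the scatter) and a 5.0-fold lower number from compound 2 to compound 4 (0.70 log units; beyond the scatter), both modest but beyond the scatter, while the comparison with (pyridin-2-yl)amino gives a 1.6-fold lower number from compound 1 to compound 4 (0.21 log units; within the scatter), which is within it, so compound 1 and compound 4 cannot be told apart here. A hydrogen on the attached nitrogen is therefore not needed for a low number in this assay, but the compounds shown offer no measurement that explains the gain over the ureido and thiourea groups.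

The compounds shown leave open whether the methyl group or the second ring nitrogen of 4-methylpiperazin-1-yl matters, a question that piperazin-1-yl without the methyl, or morpholin-4-yl with an oxygen in that ring, could settle. They also leave open whether the ring itself matters, which an open-chain dimethylamino group at the same carbon could test.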